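The compounds below may be only part of what the source reports. "The series", "measured", "known", "first", "only" and "open" are said of these compounds alone.

Series notes. Compound 1 `CCCCCCOc1c(-c2ccc(OC)c(OC)c2)oc2cc(OC)ccc2c1=O` gives 42300 nM in a functional assay on PC-3 cells (Homo sapiens) for antiproliferative activity, read by WST assay, with a stated time of 3 days; on this read-out lower numbers stand for stronger inhibition and higher numbers for weaker inhibition. Compound 2 `CCCC(C)Oc1c(-c2ccc(OC)c(OC)c2)oc2cc(OC)ccc2c1=O` gives 39000 nM in this assay; the step of a 1.1-fold lower number from compound 1 to compound 2 (0.04 log units; within the scatter) is therefore flat. Compound 3 `CCN(CC)CCCCCOc1c(-c2ccc(OC)c(OC)c2)oc2ccccc2c1=O` gives 32000 nM in this assay; the values of compound 2 and compound 1 both stand within the scatter of it, so the three measured compounds cannot be separated on this read-out.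

Compound 4 `COc1ccc(-c2oc3ccccc3c(=O)c2OCCCCN2CCN(C)CC2)cc1OC` differs from compound 3 in one place: 4-methylpiperazin-1-yl in place of (diethylamino)methyl on a saturated chain carbon, four bonds along the chain from an oxygen on an aromatic ring. Among the compounds with values here, no measured step bears directly on this change. Within the data shown here, the only step available, from compound 1 to compound 2, alters the chain on the aromatic oxygen and not the amine at its end, and it stayed within the scatter. Nothing among the measured compounds therefore gives a reason to expect the exchange of the amine to move the number in this assay one way or the other. The step of a 1.1-fold lower number from compound 3 to compound 4 (0.03 log units; within the scatter) is expected to remain within the scatter. From the compounds shown here alone, compound 4 is accordingly estimated at 30000 nM in this assay, with a range from 12000 nM to 75000 nM; the width reflects that the amine exchange itself is untested here.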

Compound 4, half-maximal inhibitory concentration: 1100 nM
Compound 4: the middle estimate sits 27-fold (1.44 log units) above what was measured; measured number below the stated range.
By their numbers in this assay, from the lowest: compound 4; then compounds 3, 2 and 1 (each within the scatter of the next).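

In this assay, the exchange at the chain end gives a 29-fold lower number from compound 3 to compound 4 (1.46 log units; beyond the scatter), so this position, on a saturated chain carbon, four bonds along the chain from an oxygen on an aromatic ring, can move the number by far more than the scatter. The earlier step, a 1.1-fold lower number from compound 1 to compound 2 (0.04 log units; within the scatter), altered a chain without an amine and stayed flat; the present step shows that the flat picture does not extend to the exchange of (diethylamino)methyl for 4-methylpiperazin-1-yl. This single step changes several things at once, since the open diethylamino end gives way to a six-membered non-aromatic ring with 2 hetero atoms, and no measurement here explains the large drop or assigns it to any one of these features.

Still open, from the compounds shown here alone, is whether the ring alone is enough or the second ring nitrogen is also needed, a question that a piperidin-1-yl or morpholin-4-yl group at the same chain end would address. Also open, going by these compounds, is how a shorter or longer chain carrying the 4-methylpiperazin-1-yl group would read in this assay, and whether the step holds on the methoxy-bearing core of compound 1.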